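The source may report more compounds than this note shows. Statements on the series, on what has been measured and on what is new or still open speak of the compounds shown alone.

Measured so far in a functional assay on MCF7 cells (Homo sapiens) for inhibition, read by MTT assay, with a stated time of 72 h, tested at 10 uM; a higher number here means more inhibition at the concentration tested (going by the name of the read-out), a lower number less inhibition: compound 1 `CCOC(=O)C1=C(Nc2ccccc2)S/C(=C\c2ccc(O)c(O)c2)C1=O` gives 38.1%. Compound 2 `CCOC(=O)C1=C(Nc2ccccc2Br)S/C(=C\c2ccc[nH]2)C1=O` gives 29.4%. Compound 3 `CCOC(=O)C1=C(Nc2ccc(C)cc2)S/C(=C\c2ccc[nH]2)C1=O` reports only a limit of the assay, < 10%, which is the limit of < 10% in this assay, at which 1 of the 3 values shown sits.

Compound 1 holds the higher of the two numbers, with compound 2 nearest, lower by an amount within the scatter, so the two cannot be ordered. Going by the values given here, the single measured step, a number at least 19.4 percentage points lower from compound 2 to compound 3 (beyond the scatter), concerns the ring on the amine nitrogen and says nothing about the other end of the shared core. Compound 4 `CCOC(=O)C1=C(Nc2ccccc2)S/C(=C\c2cc3cccnc3[nH]2)C1=O` differs from compound 1 at that other end: a group of 9 heavy atoms (7 carbon, 2 nitrogen; one five-membered aromatic ring with 1 hetero atom, one six-membered aromatic ring with 1 hetero atom) in place of a group of 8 heavy atoms (6 carbon, 2 oxygen; one six-membered aromatic ring of carbon only), on a double-bonded chain carbon bound to a double-bonded ring carbon. Among the compounds with values here, no measured step bears on this change; compounds 1 and 2 differ in two places at once and offer only their two values. A step of no size beyond the scatter is therefore expected, a number 6.1 percentage points lower from compound 1 to compound 4 (within the scatter). For compound 4 the estimate is 32%, between 12% and 50%.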

Compound 4, a percentage reported as inhibition, at one concentration (the size of the read-out at that concentration, not a potency): 18.2%
For compound 4 the middle estimate is 13.8 percentage points above the measured one, within the range that was stated.
By their numbers in this assay, from the lowest: compound 4; then compounds 2 and 1 (each within the scatter of the next). At a limit, below all of these: compound 3.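

Going by these compounds alone, this is the first step read at this place, on a double-bonded chain carbon bound to a double-bonded ring carbon, and it shows that the result in this assay depends on the group there. Replacing 3,4-dihydroxyphenyl with the group of one five-membered and one six-membered aromatic ring gives a number 19.9 percentage points lower from compound 1 to compound 4 (beyond the scatter). Nothing available accounts for this step.

Still open, as far as these compounds go, is how a phenyl with a single hydroxyl or a methoxy would read at this place. Also open, from the compounds shown here alone, is whether an amine or a carboxylic acid on that ring would change the number.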